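Halogen swap on the fused ring of compound 2

This account rests on a few compounds, and the source may have more. Where it says the series, first, only, none or still open, it means among the compounds named here.

Compound 1 `O=C1Nc2ccc(F)cc2/C1=N/NC(=S)Nc1ccc(Cl)cc1` gives 25000 nM in a functional assay on CCRF-CEM cells (Homo sapiens), with a stated time of 72 h; on this read-out lower numbers stand for stronger inhibition and higher numbers for weaker inhibition. Compound 2 `O=C1/C(=N\NC(=S)Nc2ccc(Cl)cc2)c2cc(F)ccc2N1Cc1ccc(F)cc1` gives 56000 nM and stands highest of the three numbers; compound 3 `Cc1ccc(NC(=S)N/N=C2\C(=O)N(Cc3ccc(F)cc3)c3ccc(F)cc32)cc1` gives 2500 nM, the lowest. The two measured steps are a 2.2-fold higher number from compound 1 to compound 2 (0.35 log units; beyond the scatter) and a 22-fold lower number from compound 2 to compound 3 (1.35 log units; beyond the scatter). Compound 4 `O=C1/C(=N\NC(=S)Nc2ccc(Cl)cc2)c2cc(Br)ccc2N1Cc1ccc(F)cc1` is not yet measured; it differs from compound 2 by bromo in place of fluoro on an aromatic carbon. Neither measured step bears directly on this change: one alters the nitrogen substituent, the other the group on the pendant aryl ring, and no halogen-for-halogen exchange on the fused ring has been tested within the series. The move from compound 2 to compound 4 is therefore expected to stay within the usual scatter, with no settled direction, so a 1.2-fold lower number from compound 2 to compound 4 (0.09 log units; within the scatter) is the estimated step. Compound 4 is expected to give about 45000 nM in this assay, within a range of 15000 nM to 130000 nM.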

Compound 4, half-maximal inhibitory concentration: 61000 nM
Estimate against measurement, compound 4: 1.4-fold (0.13 log units) below; the measured number falls inside the stated range.
By their numbers in this assay, from the lowest: compound 3; then compound 1; then compounds 2 and 4 (each within the scatter of the next).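

In this assay, bromo in place of fluoro on an aromatic carbon of the fused system gives a 1.1-fold higher number from compound 2 to compound 4 (0.04 log units; within the scatter), so this read-out does not separate the two halogens at this carbon. The earlier steps shown here concerned the amide-type nitrogen and the pendant aryl ring; this step adds that, with 4-fluorobenzyl on that nitrogen and chloro on the pendant ring, the change of halogen leaves compound 4 level with compound 2. No accompanying measurement is available to explain this result.

From the compounds shown here alone, whether this carbon accepts groups other than halogens remains open; a methoxy group, an amine or a carboxylic acid there would test it. Also open, going by these compounds, is whether fluoro and bromo stay level when methyl sits on the pendant ring, as in compound 3, or when the amide hydrogen is kept, as in compound 1.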